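A few compounds are considered here, and "the series" means these few. Any claim that something is new, unique, unknown or untested is made for them only; others in the source may bear on it.

Compound 1, `O=C(NCc1ccc(OCc2ccccc2)cc1)n1cccn1`, in an assay on membranes from brain for binding affinity to neutral cholesterol ester hydrolase 1 (Mus musculus), read by fluorescence, with stated times of 1 h and 30 min (a lower number here means a stronger inhibitor, a higher number a weaker inhibitor), reaches only the assay limit, > 100000 nM.
Compound 2, `N#Cc1cnn(C(=O)NCc2ccc(OCc3ccccc3)cc2)c1`, in this assay likewise shows only a limit, > 100000 nM.
Compound 3, `CN(CCN(C)C(=O)n1cccn1)Cc1ccc(OCc2ccccc2)cc1`, in this assay also gives a limit, > 100000 nM.

Compound 2 therefore stands at the ceiling of what this assay can report, not at a number. The unmeasured compound 4, `N#Cc1cnn(C(=O)NCc2ccc(OC(c3ccccc3)c3ccccc3)cc2)c1`, differs from it by phenyl in place of hydrogen on a saturated chain carbon bound to an aromatic carbon and an oxygen on an aromatic ring. Among the compounds with values here, the one measured step, a step that the two limits leave unreadable from compound 1 to compound 2, cannot be read because of the limit of > 100000 nM in this assay, at which 3 of the 3 values shown sit, so no measured step tells how large a change to expect, or in which direction. With every measured value sitting at the same limit, compound 4 is expected to stay there as well, its estimated value being 100000 nM, with a range from 20000 nM to 300000 nM, which means an expected step of a number no higher from compound 2 to compound 4 (the limit leaves the size open).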

Compound 4, half-maximal inhibitory concentration: > 100000 nM
Compound 4 gave a limit, no number; the forecaster's own chance of this, stated with the estimate: 80%; the middle value sits exactly at the limit.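

The step from compound 2 to compound 4 cannot be read, since both values are limits, not numbers: the limit of > 100000 nM in this assay, at which 4 of the 4 values shown sit.
The compounds shown leave open which structural change, if any, would give a measurable value in this assay at all.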